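The source may hold more compounds than are shown below. What is called first, only, known or untested is meant among the compounds shown, and "the series" means these compounds.

Measured compounds:
compound 1 `CCN(CC)CCCn1c(=O)c(=Cc2ccc(F)cc2F)s/c1=C1\C(=O)Nc2ccccc21` — > 200000 nM
compound 2 `CCN(CC)CCCn1c(=O)c(=Cc2ccccc2O)s/c1=C1\C(=O)Nc2ccc(Br)cc21` — 18100 nM

In a functional assay on HT-29 cells (Homo sapiens) for inhibition, read by MTT assay, with a stated time of 72 h (a lower number here means a stronger inhibitor, a higher number a weaker inhibitor), compound 1 reports only a limit, > 200000 nM, not a number. Within the data shown here, compound 2 gives 18100 nM in this assay, the only number among the values shown. The other value shown, that of compound 1, is a limit: the limit of > 200000 nM in this assay, at which 1 of the 2 values shown sits.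

Compound 3, `CCN(CC)CCCn1c(=O)c(=Cc2ccccc2O)s/c1=C1\C(=O)Nc2ccccc21`, differs from compound 2 by hydrogen in place of bromo on an aromatic carbon. Among the measured compounds shown here, no measured pair shows this change alone; compound 1 also lacks the bromo but differs in a second place as well. In this assay a modest loss beyond the scatter is expected, toward weaker inhibition. Compound 3 is expected to give about 40000 nM, between 12000 nM and 150000 nM. That estimate means an expected step of a 2.2-fold higher number from compound 2 to compound 3 (0.34 log units; beyond the scatter).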

Compound 3, half-maximal inhibitory concentration: > 200000 nM
Compound 3 ended at the assay's limit (the forecaster's own chance of this, stated with the estimate: 25%); middle value at least 5.0-fold (0.69 log units) from the limit.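

In this assay hydrogen in place of bromo on this aromatic carbon, the first change seen alone, gives an at least 11-fold higher number from compound 2 to compound 3 (1.04 log units; beyond the scatter) and so shows that, with the 2-hydroxyphenyl group held fixed, the bromo separates a measurable number from none. Compound 3 reports only a limit, and so does compound 1: the limit of > 200000 nM in this assay, at which 2 of the 3 values shown sit. The step between these two cannot be read, so 2-hydroxyphenyl and 2,4-difluorophenyl cannot be ranked without the bromo. As far as these compounds go, whether chloro, methyl or methoxy on this carbon would also give a number stays open. So does whether bromo would give one alongside 2,4-difluorophenyl.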